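Extending the linker while dropping the fluorine

The source may report more compounds than this note shows. Statements on the series, on what has been measured and on what is new or still open speak of the compounds shown alone.

Compound 1, `O=C(O)c1csc([C@H]2CC[C@@H]3[C@@H](COc4ccc(OC(F)(F)F)cc4)[C@H](O)C[C@@H]3O2)n1`, gives 14 nM in a functional assay on CHO cells for agonist activity at prostaglandin E2 receptor EP2 subtype (Homo sapiens), read by HTRF and cAMP accumulation, with a stated time of 30 min; a lower number here means that less compound is needed, a higher number that more compound is needed for the effect.
Compound 2, `O=C(O)c1csc([C@H]2CC[C@@H]3[C@@H](COc4ccc(F)cc4)[C@H](O)C[C@@H]3O2)n1`, gives 7 nM in this assay.
Compound 3, `O=C(O)c1csc([C@H]2CC[C@@H]3[C@@H](COc4ccccc4C(F)(F)F)[C@H](O)C[C@@H]3O2)n1`, gives 0.5 nM in this assay.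

All three share one core and differ only in the aryl ether hanging from it. Compound 2 stands second highest of the three numbers: a 2.0-fold lower number from compound 1 to compound 2 (0.30 log units; within the scatter), so compound 1 and compound 2 cannot be told apart, whereas a 14-fold lower number from compound 2 to compound 3 (1.15 log units; beyond the scatter), a clear separation.

Compound 4, `O=C(O)c1csc([C@H]2CC[C@@H]3[C@@H](CCOc4ccccc4)[C@H](O)C[C@@H]3O2)n1`, is the next step from compound 2: phenoxymethyl in place of 4-fluorophenoxy on a saturated chain carbon bound to a saturated ring carbon. Two things happen at once, the fluorine on the ring is removed and the chain between the core and the ether oxygen grows by one carbon. The step from compound 1 to compound 2 shows that swapping one ring substituent for another on this ring moved little, which speaks for a small effect of losing the fluorine. Within the data shown here, no measured compound varies the chain length, so that part of the change is untested. The expectation is therefore a modest shift toward a higher number, a 2.9-fold higher number from compound 2 to compound 4 (0.46 log units; beyond the scatter), with wide uncertainty. Compound 4 is expected to give 20 nM in this assay, within 4 nM to 100 nM.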

Compound 4, half-maximal effective concentration: 1.4 nM
Beside the measured number, compound 4's estimate is 14-fold (1.15 log units) above it, outside the stated range (below it).
By their numbers in this assay, from the lowest: compound 3; then compound 4; then compounds 2 and 1 (each within the scatter of the next).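

Among these compounds, this step reaches beyond the earlier compounds, which varied only what sits on the aromatic ring at a fixed distance from the shared core. Replacing the (4-fluorophenoxy)methyl group with 2-phenoxyethyl gives a 5.0-fold lower number from compound 2 to compound 4 (0.70 log units; beyond the scatter) in this assay, so a longer chain combined with an unsubstituted ring is compatible with a low number, and this position responds to more than the choice of ring substituent. The data shown offer no measurement that accounts for this drop.

Because the chain and the ring changed together, the compounds shown leave open how much of the step belongs to the added carbon and how much to the lost fluorine. A 2-(4-fluorophenoxy)ethyl group would keep the fluorine on the longer chain and so separate the two changes, while a 3-phenoxypropyl group would show whether lengthening the chain further continues the same trend or reverses it.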